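The source may report more compounds than this note shows. Statements on the series, on what has been measured and on what is new or still open speak of the compounds shown alone.

The shared core carries an amide on one side; compound 1 `C=CC(=O)Nc1cccc(-c2nc3ccccc3s2)c1` bears a vinyl on the carbonyl carbon, and compound 2 `CC(Cl)C(=O)Nc1cccc(-c2nc3ccccc3s2)c1` a 1-chloroethyl there. In an ADME assay on BJ cells (Homo sapiens) for inhibition, with a stated time of 72 h (a higher number here means that more compound is needed for the effect, a lower number that less compound is needed), compound 1 gives > 25000 nM, which is a limit of the assay rather than a number. In this assay compound 2 likewise gives > 25000 nM, again a limit and not a number. Among the compounds with values here, the single measured step, a step that the two limits leave unreadable from compound 1 to compound 2, therefore cannot be read, since both of its ends sit at the limit of > 25000 nM in this assay, at which 2 of the 2 values shown sit. Compound 2 thus stands at a limit only, with no number to place it. Compound 3 `CC(C)(CCl)C(=O)Nc1cccc(-c2nc3ccccc3s2)c1` carries the change (1-(chloromethyl)-1-methylethyl in place of 1-chloroethyl on a carbonyl carbon). Within the data shown here, no measured step bears readably on this change, and the only evidence is the limit of > 25000 nM in this assay, at which 2 of the 2 values shown sit. The step that the limit leaves unreadable from compound 2 to compound 3 is expected to stay unreadable in the same way, ending at a limit. Compound 3 is estimated at 40000 nM, within 15000 nM to 150000 nM, in this assay.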

Compound 3, half-maximal effective concentration: > 25000 nM
Compound 3 gave a limit, no number; the forecaster's own chance of this, stated with the estimate: 85%; the middle value is on the limit's open side.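

Compound 3, like compound 1 and compound 2, ends at a limit and not a number, so neither new step, to compound 3 from compound 2 or from compound 1, can be read: the limit of > 25000 nM in this assay, at which 3 of the 3 values shown sit.

The compounds shown leave open whether these three differ at all in this assay.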